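This account rests on a few compounds, and the source may have more. Where it says the series, first, only, none or still open, it means among the compounds named here.

Measured so far:
Compound 1 `Oc1cccc(-c2cc(-c3ccccc3F)cc(-c3ccccc3O)n2)c1`: in a functional assay on HCT-15 cells (Homo sapiens) for inhibition (a higher number here means a weaker inhibitor, a lower number a stronger inhibitor), compound 1 gives 8470 nM.
Compound 2 `Oc1cccc(-c2cc(-c3ccc(C(F)(F)F)cc3)cc(-c3ccccc3O)n2)c1`: compound 2 gives > 50000 nM, which is a limit of the assay rather than a number.

Among the compounds with values here, compound 1 thus holds the only number in this assay; the other value is a limit (the limit of > 50000 nM in this assay, at which 1 of the 2 values shown sits). Compound 3 `Oc1cccc(-c2cc(-c3ccccc3OC(F)(F)F)cc(-c3ccccc3O)n2)c1` differs from compound 1 in one place: trifluoromethoxy in place of fluoro on an aromatic carbon. Within the data shown here, the single measured step, an at least 5.9-fold higher number from compound 1 to compound 2 (0.77 log units; beyond the scatter), also brought a trifluoromethyl group onto that ring and weakened inhibition, though it swapped the whole ring. A higher number is therefore expected for compound 3, a 3.0-fold higher number from compound 1 to compound 3 (0.47 log units; beyond the scatter). The estimate for compound 3 is 25000 nM, between 8000 nM and 60000 nM.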

Compound 3, half-maximal inhibitory concentration: 3240 nM
Compound 3: middle estimate off by 7.7-fold (0.89 log units), on the high side; the whole stated range lies above it.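

In this assay trifluoromethoxy in place of fluoro gives a 2.6-fold lower number from compound 1 to compound 3 (0.42 log units; beyond the scatter) and so a stronger inhibitor. This position, ortho to a large group, therefore takes a group with more heavy atoms than fluoro, and inhibition still improves. No measurement shown here explains this gain.

Going by these compounds, whether the gain depends on the fluorine atoms stays open, since only fluoro and trifluoromethoxy have been compared at this position. A methoxy group, an amine or a carboxylic acid there could help to settle what this position accepts.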